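A few compounds are considered here, and "the series" means these few. Any claim that something is new, unique, unknown or untested is made for them only; others in the source may bear on it.

Measured so far:

Compound 1, `CCCOc1cc(C)c(-c2cccc(COc3ccc(S(=O)(=O)CC(=O)O)cc3)c2)c(C)c1`: 69.2 nM
Compound 2, `O=C(O)CS(=O)(=O)c1ccc(OCc2cccc(-c3ccccc3)c2)cc1`: 288 nM
Compound 3, `Cc1nc(-c2ccccc2)sc1COc1ccc(S(=O)(=O)CC(=O)O)cc1`: 331 nM

All three share a sulfonylacetic acid head on a phenyl ether, and all were measured in a functional assay on CHO cells for agonist activity at Free fatty acid receptor 1 (Homo sapiens), read by FLIPR and calcium flux; on this read-out higher numbers stand for an effect only at larger amounts of compound and lower numbers for an effect already at smaller amounts. Compound 3 gives the highest of the three numbers in this assay. Its nearest neighbour is compound 2, whose value sits within the usual scatter of compound 3, so the two cannot be told apart. Compound 1 lies furthest away, with a number well below that of compound 3, a gap beyond the scatter.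

Compound 4, `Cc1nc(-c2cccc(Cl)c2)sc1COc1ccc(S(=O)(=O)CC(=O)O)cc1`, is not yet measured. It differs from compound 3 in one place: chloro in place of hydrogen on an aromatic carbon. Read one bond further out, the change is phenyl to 3-chlorophenyl, with the new atom sitting meta to a large group.

Going by the values given here, no measured pair in this set shows what such a single chloro substitution does, so the expectation rests on compound 3 alone. The step from compound 3 to compound 4 is expected to be small, likely toward a lower number but possibly not beyond the scatter: a 1.7-fold lower number from compound 3 to compound 4 (0.22 log units; within the scatter). For compound 4 the estimated value in this assay is 200 nM, with a plausible range from 70 nM to 600 nM.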

Compound 4, half-maximal effective concentration: 251 nM
Estimate against measurement, compound 4: 1.3-fold (0.10 log units) below; the range from low to high includes it.
By their numbers in this assay, from the lowest: compound 1; then compounds 4, 2 and 3 (each within the scatter of the next).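

Going by these compounds alone, compound 3 and compound 4 form the first pair here that differs in only one place, so the effect of a single substitution can now be read directly. Replacing hydrogen with chloro, which turns phenyl into 3-chlorophenyl, gives a 1.3-fold lower number from compound 3 to compound 4 (0.12 log units; within the scatter), so at this position the added chlorine atom produces no difference that can be told apart from the usual scatter. This single pair shows that the chloro is tolerated here, but no available evidence explains the result.

Going by these compounds, it remains open whether a methoxy group, a nitrile or an amine at the same position would also leave the value within the scatter. Also unresolved is whether chloro would behave the same way on another carbon of that ring, or on the phenyl of compound 2.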